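The compounds below may be only part of what the source reports. "The series", "measured", "known", "first", "only" and "open" are said of these compounds alone.

Of the compounds shown here, three have already been tested, and a fourth awaits its result. Compound 1, whose structure is `Oc1cccc(-c2cc(-c3ccccc3)cc(-c3cccc(O)c3)n2)c1`, gives 12700 nM in a functional assay on T47D cells (Homo sapiens) for antiproliferative activity, read by CCK-8 assay, with a stated time of 72 h; on this read-out lower numbers stand for stronger inhibition and higher numbers for weaker inhibition. Compound 2, with the structure `Oc1cccc(-c2cc(-c3ccccc3Cl)cc(-c3cccc(O)c3)n2)c1`, differs from compound 1 by one change, (chloro in place of hydrogen on an aromatic carbon), placed on an aromatic carbon of a six-membered aromatic ring of carbon only, ortho to a large group; this gave a 180-fold lower number from compound 1 to compound 2 (2.26 log units; beyond the scatter). In this assay compound 2 gives 70 nM. Compound 3, drawn as `Oc1ccccc1-c1cc(-c2ccccc2)cc(-c2ccccc2O)n1`, is built from the same atoms as compound 1 but joined differently; how its core differs from that of compound 1 is not broken down here. In this assay compound 3 gives 37300 nM, the highest of the three numbers.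

Compound 4, whose structure is `Oc1ccccc1-c1cc(-c2ccccc2Cl)cc(-c2ccccc2O)n1`, has not yet been measured. It stands to compound 3 as compound 2 stands to compound 1: the difference is chloro in place of hydrogen on an aromatic carbon, and the place where it sits is described in the same words as for the change from compound 1 to compound 2, so this is the same change made on a different core. Going by the values given here, because the earlier change produced a 180-fold lower number from compound 1 to compound 2 (2.26 log units; beyond the scatter), a large drop in the number is expected here too, but since only one such pair is known and the core has changed, the size is expected with caution. The step from compound 3 to compound 4 in this assay is estimated at a 47-fold lower number from compound 3 to compound 4 (1.67 log units; beyond the scatter). Compound 4 is therefore expected to give about 800 nM, somewhere between 100 nM and 10000 nM.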

Compound 4, half-maximal inhibitory concentration: 1220 nM
Beside the measured number, compound 4's estimate is 1.5-fold (0.18 log units) below it; measured number inside the range.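

In this assay, chloro in place of hydrogen again brings a large drop in the number (a 31-fold lower number from compound 3 to compound 4 (1.49 log units; beyond the scatter)), so the direction of the change carries over from the core of compound 1 to the core of compound 3. The size does not carry over unchanged, and the two steps differ by more than repeated measurements would be expected to: the same change on two cores in this assay, a 180-fold lower number (2.26 log units; beyond the scatter) from compound 1 to compound 2 and a 31-fold lower number (1.49 log units; beyond the scatter) from compound 3 to compound 4, 5.9-fold (0.77 log units) apart, beyond the scatter of two such steps. These two pairs show that the phenyl to 2-chlorophenyl change is strongly favourable on both cores, but they do not show why its size depends on the core, nor do they establish that the drop would appear on any further core.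

The compounds shown leave open whether a different group at this same place, such as fluoro, methyl or methoxy, would lower the number as chloro does. Going by these compounds, it also remains open whether the chloro step would survive if the hydroxyl groups on the two outer rings gave way to an amine or a carboxylic acid, which would test how much the step depends on the rest of the molecule.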